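This account rests on a few compounds, and the source may have more. Where it says the series, first, only, none or still open, it means among the compounds named here.

Measured so far in an ADME assay (liver) for metabolic stability, with Liver microsome (Homo sapiens) as the target, using microsomes; on this read-out lower numbers stand for a shorter-lived compound and higher numbers for a longer-lived compound:

Compound 1 `CCc1nc2cc(Cl)ccn2c1C(=O)NCc1ccc(-c2ccc(C)cc2)cc1` gives 0.423 h
Compound 2 `CCc1nc2cc(Cl)ccn2c1C(=O)NCc1ccc(-c2ccc[nH]2)cc1` gives > 2 h (a limit, not a number)
Compound 3 `CCc1nc2cc(Cl)ccn2c1C(=O)NCc1ccc(-c2ccncc2)cc1` gives 0.482 h

Compound 3 stands level with compound 1, the two lying within the scatter of each other (a 1.1-fold higher number from compound 1 to compound 3 (0.06 log units; within the scatter)). The result for compound 2 is a limit (the limit of > 2 h in this assay, at which 1 of the 3 values shown sits). The steps involving compound 2 both lie beyond the scatter (an at least 4.7-fold higher number from compound 1 to compound 2 (0.67 log units; beyond the scatter) and an at least 4.1-fold lower number from compound 2 to compound 3 (0.61 log units; beyond the scatter)).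

Compound 4 `CCc1nc2cc(Cl)ccn2c1C(=O)NCc1ccc(N2CCCCC2)cc1` has piperidin-1-yl in place of pyridin-4-yl on an aromatic carbon. Among the measured compounds shown here, no measured compound carries a six-membered non-aromatic ring at this place, so no measured step covers the change directly. The closest guide is the exchange between the two six-membered aromatic rings, which stayed within the scatter (a 1.1-fold higher number from compound 1 to compound 3 (0.06 log units; within the scatter)). Compound 2 goes against reading this place as indifferent to change (an at least 4.7-fold higher number from compound 1 to compound 2 (0.67 log units; beyond the scatter)), so the upper side of the range is left wide. The expected outcome is therefore no step beyond the scatter, in either direction. This estimate means a 1.2-fold lower number from compound 3 to compound 4 (0.08 log units; within the scatter) as the expected step. For compound 4 the estimated half-life is 0.4 h, with an expected range from 0.17 h to 1 h.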

Compound 4, half-life: 0.22 h
Compound 4: middle estimate off by 1.8-fold (0.26 log units), on the high side, and the stated range covers the measured number.
By their numbers in this assay, from the lowest: compounds 4, 1 and 3 (each within the scatter of the next, the first and the last beyond it). At a limit, above all of these: compound 2.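

In this assay, a non-aromatic ring at this place gives a step that the exchange between the two six-membered aromatic rings did not: piperidin-1-yl in place of pyridin-4-yl, with the same count of heavy atoms and hydrogen-bond acceptors, gives a 2.2-fold lower number from compound 3 to compound 4 (0.34 log units; beyond the scatter). The change is not uniform across the aromatic groups, as piperidin-1-yl in place of 4-methylphenyl gives only a 1.9-fold lower number from compound 1 to compound 4 (0.28 log units; within the scatter), so no order can be drawn within that pair. The largest gap is an at least 9.0-fold lower number from compound 2 to compound 4 (0.95 log units; beyond the scatter), which leaves 1H-pyrrol-2-yl alone at the top of the series, but compound 2 holds a limit and not a number: the limit of > 2 h in this assay, at which 1 of the 4 values shown sits.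

The compounds shown leave open whether the lower number for compound 4 belongs to the non-aromatic ring itself or to a ring nitrogen sitting on the aromatic carbon, a question that cyclohexyl set against piperidin-1-yl would address. They also leave open whether the result for compound 2 is particular to 1H-pyrrol-2-yl or extends to other five-membered rings such as furan-2-yl or 1H-pyrazol-3-yl.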